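Replacing the 4-chlorophenyl of compound 1 with oxan-4-yl

This account rests on a few compounds, and the source may have more. Where it says the series, first, only, none or still open, it means among the compounds named here.

For the measured compounds named here, in an ADME assay on microsomes from liver (Rattus norvegicus) for metabolic stability, read by LC-MS, tested at 1 uM (on this read-out higher numbers stand for a more stable compound and lower numbers for a less stable compound), compound 1 (`CS(=O)(=O)NC(=O)CCc1cn(-c2ccc(Br)cc2)nc1-c1ccc(Cl)cc1`) gives 74%, the lower of the two exact numbers measured so far. The other belongs to compound 3 (`CS(=O)(=O)NC(=O)CCc1cn(-c2ccc(Br)cc2)nc1-c1cccnc1`), which gives 95%. Compound 2 (`CS(=O)(=O)NC(=O)CCc1cn(-c2ccc(Cl)cc2)nc1-c1ccc(Cl)cc1`) reads > 99%, and this is a limit of the assay, not a number.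

Compound 4 (`CS(=O)(=O)NC(=O)CCc1cn(-c2ccc(Br)cc2)nc1C1CCOCC1`) carries oxan-4-yl in place of 4-chlorophenyl on an aromatic carbon. The closest guide is compound 3, where pyridin-3-yl took the place of the same 4-chlorophenyl, giving a number 21 percentage points higher from compound 1 to compound 3 (beyond the scatter). This guide is only partial, since oxan-4-yl is a non-aromatic ring. Going by the values given here, the step to compound 2 changes the bromo instead, giving a number at least 25 percentage points higher from compound 1 to compound 2 (beyond the scatter), so it bears less directly and shows only that a single change can lift compound 1 well beyond the scatter. In this assay a rise of roughly the size seen for compound 3 is expected, and the estimated step is a number 16 percentage points higher from compound 1 to compound 4 (beyond the scatter). For compound 4 the expected value is 90%, within an estimated range of 74% to 99%.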

Compound 4, percent of the compound remaining: 83%
The estimate for compound 4 lay 7 percentage points above the measured number; the measured number falls inside the stated range.
By their numbers in this assay, from the lowest: compounds 1 and 4 (each within the scatter of the next); then compound 3. At a limit, above all of these: compound 2.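

In this assay, replacing the 4-chlorophenyl with oxan-4-yl does not clearly separate the new compound from its parent, the change giving a number 9 percentage points higher from compound 1 to compound 4 (within the scatter). What enters at this position still matters. The two replacement rings do not read alike, with a number 12 percentage points lower from compound 3 to compound 4 (beyond the scatter). So losing the 4-chlorophenyl does not by itself bring the rise seen with pyridin-3-yl, and nothing measured here explains why these two rings differ.

Still open, from the compounds shown here alone, is how other groups at this position would read, such as a piperidine ring, which carries an amine, or an open alkyl chain in place of a ring. Also open, going by these compounds, is whether oxan-4-yl would behave the same way on a core with chloro in place of bromo.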